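Azetidinyl replacing fluoropyridinyl on the shared pyridine amide core

This account rests on a few compounds, and the source may have more. Where it says the series, first, only, none or still open, it means among the compounds named here.

Measured so far in an assay on CHO cells for antagonist activity at Orexin/Hypocretin receptor type 1 variant I408V (Homo sapiens), read by FLIPR, with a stated time of 5 min; on this read-out higher numbers stand for weaker inhibition and lower numbers for stronger inhibition:
- compound 1 `COc1ccc(CNC(=O)c2cc(-c3cncc(C)c3)ncc2-c2cncc(F)c2)nc1OC`: 10000 nM
- compound 2 `COc1ccc(CNC(=O)c2cc(-c3cncc(C)c3)ccc2-c2ccccc2)nc1OC`: 1540 nM
- compound 3 `COc1ccc(CNC(=O)c2nc(-c3cncc(C)c3)ncc2-c2ccccc2)nc1OC`: a limit of the assay, > 10000 nM

Compound 1 holds the highest of the two numbers that are actual numbers in this assay; compound 2 sits at a lower number, and the gap between the two lies beyond the usual scatter. The third value is not a number but a limit (the limit of > 10000 nM in this assay, at which 1 of the 3 values shown sits), so compound 3 cannot be placed against compound 1 in size.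

Compound 4 `COc1ccc(CNC(=O)c2cc(-c3cncc(C)c3)ncc2N2CCC2)nc1OC` is compound 1 with one change, (azetidin-1-yl in place of 5-fluoropyridin-3-yl on an aromatic carbon). Among the compounds with values here, no pair of measured compounds differs in this one place, so the size and direction of the step are unsupported by measured steps. Both neighbours of compound 1 either sit at the limit or near it, which leaves the series weakly active overall, and a shift in either direction is possible. The expectation for the step from compound 1 to compound 4 is a 1.7-fold lower number from compound 1 to compound 4 (0.22 log units; within the scatter), with no clear direction beyond the scatter. Compound 4 is accordingly estimated at 6000 nM, in a range from 800 nM to 30000 nM.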

Compound 4, half-maximal inhibitory concentration: 10000 nM
Compound 4: the middle estimate sits 1.7-fold (0.22 log units) below what was measured; low and high end bracket the measured number.
By their numbers in this assay, from the lowest: compound 2; then compounds 1 and 4 (each within the scatter of the next).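

Replacing 5-fluoropyridin-3-yl with azetidin-1-yl on this aromatic carbon gives, in this assay, no change at the digits printed from compound 1 to compound 4 (within the scatter). Within the data shown here, this is the first reading at this position: a six-membered aromatic ring and a smaller four-membered non-aromatic ring are not told apart by this read-out, so the aromatic ring is not needed here to hold the number of compound 1, and the smaller group brings no gain. Compound 3 stands at a limit of the assay, not at a number, and takes no part in this step: the limit of > 10000 nM in this assay, at which 1 of the 4 values shown sits.

Still open, as far as these compounds go, is whether any group at this position can give a clearly lower number, for instance a morpholine, a dimethylamino group, a primary amine or a carboxylic acid, since two groups reading alike say little about the position as a whole. Also open, from the compounds shown here alone, is whether azetidin-1-yl would read the same on the core of compound 2, which carries a lower number than compound 1 in this assay.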